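The source may report more compounds than this note shows. Statements on the series, on what has been measured and on what is new or still open speak of the compounds shown alone.

In a functional assay on the whole organism for antagonist activity, with Rattus norvegicus as the target (a higher number here means that more compound is needed for the effect, a lower number that less compound is needed), compound 1 (`CN(C)C1CCN(C(=O)CCCOc2cc(C(=O)N3CCCCc4sccc43)ccc2NC(=O)c2ccccc2-c2ccccc2)CC1`) gives 0.005 mg/kg and compound 2 (`CN1CCN(C(=O)CCCOc2cc(C(=O)N3CCCCc4sccc43)ccc2NC(=O)c2ccccc2-c2ccccc2)CC1`) gives 0.03 mg/kg, so compound 2 holds the higher of the two numbers and needs more compound for the effect. Compound 3 (`CN1CCN(CCCCOc2cc(C(=O)N3CCCCc4sccc43)ccc2NC(=O)c2ccccc2-c2ccccc2)CC1`) has not yet been measured in this assay. It differs from compound 2 as follows: (4-methylpiperazin-1-yl)methyl in place of (4-methylpiperazin-1-yl)carbonyl on a saturated chain carbon, three bonds along the chain from an oxygen on an aromatic ring. The carbonyl on the chain is thus gone, while the 4-methylpiperazin-1-yl group stays. Among the measured compounds shown here, only one measured step bears on this, and only indirectly: a 6.0-fold higher number from compound 1 to compound 2 (0.78 log units; beyond the scatter). That step exchanges the group on the carbonyl carbon and keeps the carbonyl, so it gives no direction for removing it. For the measured compounds named here, it shows only that a change at this end of the chain can move the number by a modest amount. No step beyond the scatter is therefore expected, although a move of similar size in either direction would not be surprising. The expected step is a 1.3-fold higher number from compound 2 to compound 3 (0.12 log units; within the scatter). Compound 3 is estimated at 0.04 mg/kg, with an expected range from 0.008 mg/kg to 0.2 mg/kg.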

Compound 3, dose for 50% inhibition: < 0.01 mg/kg
Compound 3: no number, only a limit (the forecaster's own chance of this, stated with the estimate: 5%); at least 4.0-fold (0.60 log units) between middle value and limit.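

Compounds 1 and 2 both keep the carbonyl on the chain and so spoke only to the group attached to it, whereas compound 3 tests the carbonyl itself: replacing (4-methylpiperazin-1-yl)carbonyl with (4-methylpiperazin-1-yl)methyl gives an at least 3.0-fold lower number from compound 2 to compound 3 (0.47 log units; beyond the scatter), showing that, with the 4-methylpiperazin-1-yl group kept, the carbonyl is not required for a low number at this place in this assay. Compound 3 has no exact number in this assay, only the limit < 0.01 mg/kg. The full size of the gain therefore stays unknown and the step between compound 1 and compound 3 cannot be read, because compound 3 is held by a limit: the limit of < 0.01 mg/kg in this assay, at which 1 of the 3 values shown sits.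

The compounds shown leave open whether the same change would give a similar result with the 4-(dimethylamino)piperidin-1-yl group of compound 1, since this evidence comes from a single pair carrying the 4-methylpiperazin-1-yl group. They also leave open how a morpholine or a simple dimethylamino group at the end of the chain, or a shorter or longer chain in place of the 4-(4-methylpiperazin-1-yl)butyl, would read in this assay.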